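Diisopropylamino for dimethylamino on a carbonyl carbon

The source may hold more compounds than are shown below. What is called first, only, known or untested is meant among the compounds shown, and "the series" means these compounds.

Measured in a functional assay on SMMC-7721 cells (Homo sapiens) for antiproliferative activity, read by MTT assay, with a stated time of 48 h; on this read-out higher numbers stand for weaker inhibition and lower numbers for stronger inhibition:
- compound 1 `CC(C)=CCC[C@]1(C)/C=C/[C@@H](OC(=O)C=C(C)C)[C@](C)(O)/C=C/C(=O)/C(CN2CCCC2)=C\C1` gives 140 nM
- compound 2 `CC(C)=CCC[C@]1(C)/C=C/[C@@H](OC(=O)C=C(C)C)[C@](C)(O)/C=C/C(=O)/C(CN=[N+]=[N-])=C\C1` gives 3080 nM
- compound 3 `CC(C)=CCC[C@]1(C)/C=C/[C@@H](OC(=O)C=C(C)C)[C@](C)(O)/C=C/C(=O)/C(C(=O)N(C)C)=C\C1` gives 3670 nM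

Compound 3 stands at the weak end of this small set, level with compound 2 and far from compound 1. The measured steps are a 1.2-fold higher number from compound 2 to compound 3 (0.08 log units; within the scatter) and a 26-fold higher number from compound 1 to compound 3 (1.42 log units; beyond the scatter). Both replace another group with dimethylcarbamoyl, so neither tests the new change.

Compound 4 `CC(C)=CCC[C@]1(C)/C=C/[C@@H](OC(=O)C=C(C)C)[C@](C)(O)/C=C/C(=O)/C(C(=O)N(C(C)C)C(C)C)=C\C1` keeps the shared core and differs by diisopropylamino in place of dimethylamino on a carbonyl carbon. Among the compounds with values here, no measured pair varies the groups on that carbonyl carbon, so the data give no direction, and no step beyond the scatter is expected. The expected step is a 1.0-fold lower number from compound 3 to compound 4 (0.02 log units; within the scatter). For compound 4 the estimated value is 3500 nM, with an expected range from 1200 nM to 10000 nM.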

Compound 4, half-maximal inhibitory concentration: 17200 nM
Estimate against measurement, compound 4: 4.9-fold (0.69 log units) below, and the stated range ends below it.
By their numbers in this assay, from the lowest: compound 1; then compounds 2 and 3 (each within the scatter of the next); then compound 4.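

In this assay, within the data shown here, the groups on this carbonyl carbon clearly affect the read-out: diisopropylamino in place of dimethylamino gives a 4.7-fold higher number from compound 3 to compound 4 (0.67 log units; beyond the scatter) in the first measured change at that carbon. Diisopropylcarbamoyl also falls behind azidomethyl, with a 5.6-fold higher number from compound 2 to compound 4 (0.75 log units; beyond the scatter) on the same ring carbon, and much further behind (pyrrolidin-1-yl)methyl, with a 120-fold higher number from compound 1 to compound 4 (2.09 log units; beyond the scatter) at that place. Nothing here explains these losses. Still open, on these data alone, is how a pyrrolidin-1-yl amide, a diethylamino group or a carboxylic acid at this carbon would compare with compound 3.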